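This account rests on a few compounds, and the source may have more. Where it says the series, first, only, none or still open, it means among the compounds named here.

Compound 1 `CCc1ccccc1N(CC(=O)NCc1cccc(OC)c1)S(=O)(=O)c1ccc(C)cc1`: 138 nM in a functional assay on CHO-K1 cells for antagonist activity at prostaglandin E2 receptor EP1 subtype (Homo sapiens), read by FLIPR and calcium flux; on this read-out higher numbers stand for weaker inhibition and lower numbers for stronger inhibition
Compound 2 `CCc1ccccc1N(CC(=O)NCc1cccc(OC(F)(F)F)c1)S(=O)(=O)c1ccc(C)cc1`: 427 nM in this assay
Compound 3 `CCc1ccccc1N(CC(=O)NCc1ccc(Cl)cc1)S(=O)(=O)c1ccc(C)cc1`: 11.5 nM in this assay

Compound 3 gives the lowest number of the three; compound 1 sits a 12-fold lower number from compound 1 to compound 3 (1.08 log units; beyond the scatter) and compound 2 sits a 37-fold lower number from compound 2 to compound 3 (1.57 log units; beyond the scatter). Compound 4 `Cc1ccc(S(=O)(=O)N(CC(=O)NCc2ccc(Cl)cc2)c2cccnc2)cc1` differs from compound 3 in one place: pyridin-3-yl in place of 2-ethylphenyl on a sulfonamide nitrogen. Neither of the measured steps touches this position; a 3.1-fold higher number from compound 1 to compound 2 (0.49 log units; beyond the scatter) and a 12-fold lower number from compound 1 to compound 3 (1.08 log units; beyond the scatter) both concern the ring on the amide side. Going by the values given here, no measured step bears directly on the sulfonamide nitrogen, so the expectation rests on compound 3 alone. A modest weakening is estimated, a 5.2-fold higher number from compound 3 to compound 4 (0.72 log units; beyond the scatter), with a wide range. Compound 4 is expected to give about 60 nM in this assay, between 10 nM and 400 nM.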

Compound 4, inhibition constant: < 1450 nM
Compound 4: a limit, no number; the forecaster's own chance of this, stated with the estimate: 5%; the middle value does not contradict the limit.
By their numbers in this assay, from the lowest: compound 3; then compound 1; then compound 2.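

Compound 4 gives < 1450 nM in this assay, which is a limit and not a number, and the step from compound 3 to compound 4 cannot be read. The compounds shown leave open how pyridin-3-yl in place of 2-ethylphenyl on a sulfonamide nitrogen changes inhibition.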